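Chloro-to-hydrogen swap across two fused tricyclic cores

This account rests on a few compounds, and the source may have more. Where it says the series, first, only, none or still open, it means among the compounds named here.

Two pairs share one structural change. Compound 1 `O=C1C2=C(C(=O)c3ncccc31)C1(CS2)NC(=O)N(c2ccc(Cl)cc2)C1=O` carries a 4-chlorophenyl group on its imide nitrogen, and in a functional assay on CCRF-SB cells (Homo sapiens) for antiproliferative activity, read by MTT assay, with a stated time of 96 h (a lower number here means a stronger inhibitor, a higher number a weaker inhibitor), compound 1 gives 10 nM. Compound 2 `O=C1C2=C(C(=O)c3ncccc31)C1(CS2)NC(=O)N(c2ccccc2)C1=O` differs from it by hydrogen in place of chloro on an aromatic carbon and in this assay compound 2 gives 30 nM. The step is a 3.0-fold higher number from compound 1 to compound 2 (0.48 log units; beyond the scatter).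

Compound 3 `O=C1NN(c2ccc(Cl)cc2)C(=O)C2(CSC3=C2C(=O)c2ncccc2C3=O)N1` keeps the 4-chlorophenyl group but on a different core; the difference between the core of compound 1 and the core of compound 3 is not broken down here. In this assay compound 3 gives 51 nM, which stands within the scatter of compound 2 and beyond it from compound 1.

Compound 4 `O=C1NN(c2ccccc2)C(=O)C2(CSC3=C2C(=O)c2ncccc2C3=O)N1` is the unmeasured partner of compound 3, differing by hydrogen in place of chloro on an aromatic carbon. The place of the change is the same in both pairs, so this is the same kind of change on another core. Among the compounds with values here, only one measured instance exists, so the expectation rests on a single step. Compound 4 is expected to show a step of about a 2.7-fold higher number from compound 3 to compound 4 (0.44 log units; beyond the scatter) in this assay, because the same change read a 3.0-fold higher number from compound 1 to compound 2 (0.48 log units; beyond the scatter). Given that compound 3 starts at 51 nM, compound 4 is estimated at 140 nM, with a range of 60 nM to 350 nM to allow for the change transferring less cleanly to the second core.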

Compound 4, half-maximal inhibitory concentration: 39 nM
For compound 4 the middle estimate is 3.6-fold (0.56 log units) above the measured one; the whole stated range lies above it.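

In this assay, the change from 4-chlorophenyl to phenyl on the core of compound 3 reads as a 1.3-fold lower number from compound 3 to compound 4 (0.12 log units; within the scatter), so on this core the change does not separate the two compounds. The step seen on the core of compound 1 therefore does not carry over to the core of compound 3 at the same size, and the two cores have to be read separately for this change: the same change on two cores in this assay, a 3.0-fold higher number (0.48 log units; beyond the scatter) from compound 1 to compound 2 and a 1.3-fold lower number (0.12 log units; within the scatter) from compound 3 to compound 4, 3.9-fold (0.59 log units) apart, beyond the scatter of two such steps. This shows that a step read on one core is a poor guide to the other in this series, but with a single pair on each core it does not show what in the cores sets the two steps apart, nor whether either step is typical of its core.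

The compounds shown leave open how a fluoro, a methoxy or an amine in the place of the chloro would read on each core, and so whether the gap between the two steps is particular to chloro. They also leave open whether a carboxylic acid or a longer chain at that place would follow one core's step, the other's, or neither.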